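The source may hold more compounds than are shown below. What is called first, only, known or untested is meant among the compounds shown, and "the series" means these compounds.

Measured so far:
compound 1 `O=C(Nc1cccc(-n2cc(-c3ccncc3)c(-c3cc(O)cc(Cl)c3)n2)c1)Nc1ccc(Cl)c(C(F)(F)F)c1`, -80%
compound 2 `O=C(Nc1cccc(-n2cc(-c3ccncc3)c(-c3cc(O)cc(Cl)c3)n2)c1)Nc1ccc(Cl)c(Cl)c1`, -58%

In a functional assay on SF-295 cells (Homo sapiens) for inhibition, read by sulforhodamine B assay, with a stated time of 48 h, tested at 100 uM (a lower number here means a stronger effect, a higher number a weaker effect of the compound at the concentration tested), compound 1 gives -80%, the lowest of the two numbers. Within the data shown here, compound 2 gives -58% in this assay, and the single measured step, a number 22 percentage points higher from compound 1 to compound 2 (beyond the scatter), is a modest one that lies beyond the scatter. That step puts chloro in place of trifluoromethyl on an aromatic carbon of the urea-linked ring, a part of the molecule untouched here.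

Compound 3 `COc1cc(Cl)cc(-c2nn(-c3cccc(NC(=O)Nc4ccc(Cl)c(C(F)(F)F)c4)c3)cc2-c2ccncc2)c1` differs from compound 1 in one place: methyl in place of hydrogen on an oxygen on an aromatic ring. The change is hydroxy to methoxy, turning 3-chloro-5-hydroxyphenyl into 3-chloro-5-methoxyphenyl. Among the measured compounds shown here, no measured step concerns this oxygen; the only step known changes a different ring. The data therefore give no ground for expecting a shift beyond the scatter in this assay, and the estimate stays close to compound 1 with a widened range.

Compound 3 is expected to give about -72% in this assay, within -100% to -40%. This estimate corresponds to an expected step of a number 8 percentage points higher from compound 1 to compound 3 (within the scatter), no more than the scatter.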

Compound 3, a percentage reported as activity, at one concentration (the size of the read-out at that concentration, not a potency): -82%
Beside the measured number, compound 3's estimate is 10 percentage points above it, and the stated range covers the measured number.
By their numbers in this assay, from the lowest: compounds 3 and 1 (each within the scatter of the next); then compound 2.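

Putting methyl in place of hydrogen on this oxygen, which turns 3-chloro-5-hydroxyphenyl into 3-chloro-5-methoxyphenyl, leaves the read-out in this assay unmoved: the result is a number 2 percentage points lower from compound 1 to compound 3 (within the scatter). Among these compounds, the only earlier step, a number 22 percentage points higher from compound 1 to compound 2 (beyond the scatter), changed a different ring, so this pair gives the first reading at this oxygen and shows that, on the core of compound 1 and at the concentration tested, the hydrogen of the hydroxy group can give way to methyl with no shift that stands out from the scatter. No measurement at hand bears on why the number holds.

On these data alone, whether this oxygen position accepts more than a methyl stays open, as a longer chain such as ethoxy, or an amine or a carboxylic acid in place of the hydroxy group, could behave quite differently. As far as these compounds go, it is also open whether the methoxy group would leave the number as unmoved on compound 2, which carries chloro in place of trifluoromethyl.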